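The compounds below may be only part of what the source reports. "The series", "measured", "known", "first", "only" and "open" are said of these compounds alone.

Working notes on the series.

Of the compounds shown here, three of the shared core have been measured in a functional assay on HUVEC cells (Homo sapiens) for inhibition, read by ELISA; a higher number here means a weaker inhibitor, a lower number a stronger inhibitor. Compound 1 `CCc1nnc([S+]([O-])Cc2ncc(C)c(OC)c2C)o1` gives 10000 nM. Compound 2 `COc1c(C)cnc(C[S+]([O-])c2nnc(-c3ccccc3)o2)c1C` gives 6000 nM. Compound 3 `COc1c(C)cnc(C[S+]([O-])c2nnc(C)o2)c1C` gives 8000 nM. The whole set sits close together: a 1.7-fold lower number from compound 1 to compound 2 (0.22 log units; within the scatter), a 1.3-fold lower number from compound 1 to compound 3 (0.10 log units; within the scatter) and a 1.3-fold higher number from compound 2 to compound 3 (0.12 log units; within the scatter) are all within the scatter, so compound 3 cannot be placed above or below either of the others on the numbers shown.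

Compound 4 `COc1c(C)cnc(C[S+]([O-])c2nnc(-c3cccc(F)c3)o2)c1C` has not yet been measured in this assay. It differs from compound 3 by 3-fluorophenyl in place of methyl on an aromatic carbon. Going by the values given here, the step that bears most directly on this is the one between compound 2 and compound 3, where phenyl stands against methyl at the same place and the outcome was a 1.3-fold higher number from compound 2 to compound 3 (0.12 log units; within the scatter). The step of a 1.7-fold lower number from compound 1 to compound 2 (0.22 log units; within the scatter) points the same way, also within the scatter. Among the compounds with values here, nothing among the measured compounds shows what a fluorine on that ring does, so there is no basis for expecting compound 4 to move beyond the scatter.

Compound 4 is therefore expected to land close to compound 2 and compound 3, with a step of about a 1.3-fold lower number from compound 3 to compound 4 (0.12 log units; within the scatter). The estimate for compound 4 is 6000 nM, with a range from 3000 nM to 12000 nM.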

Compound 4, half-maximal inhibitory concentration: 12000 nM
Compound 4: middle estimate off by 2.0-fold (0.30 log units), on the low side; the measured number falls inside the stated range.
By their numbers in this assay, from the lowest: compounds 2, 3, 1 and 4 (each within the scatter of the next).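

In this assay, going by these compounds alone, the fluorine on the phenyl ring is the first change at this place made on the ring itself rather than by exchanging the whole group, and a 2.0-fold higher number from compound 2 to compound 4 (0.30 log units; within the scatter) leaves it within the scatter, so the measured compounds show no effect of this fluorine. Set against the two alkyl groups at the same aromatic carbon of the five-membered aromatic ring with 2 nitrogen and 1 oxygen, 3-fluorophenyl gives a 1.5-fold higher number from compound 3 to compound 4 (0.18 log units; within the scatter) and a 1.2-fold higher number from compound 1 to compound 4 (0.08 log units; within the scatter), which means that methyl, ethyl, phenyl and 3-fluorophenyl cannot be told apart at this place in this assay, even though the group entering has 7 heavy atoms and the group leaving has 1. No measurement at hand accounts for any of these steps.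

Open, going by these compounds, is whether any group at this place can move the number beyond the scatter, since an amine, a carboxylic acid or a longer chain on this aromatic carbon would test the position with a different kind of group. Also open, on these data alone, is what a chloro or methoxy group on the phenyl ring would do.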